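Swapping a Fluorophenyl for a Hydroxycyclopentyl on the Alkyne

The source may hold more compounds than are shown below. What is called first, only, known or untested is meant among the compounds shown, and "the series" means these compounds.

Compound 2 `O=[N+]([O-])c1c(CS(=O)(=O)c2ccccc2)nc2c(C#Cc3ccccc3F)cc(Cl)cn12` is one of three compounds tested in an ADME assay on HepG2 cells (Homo sapiens) for cytotoxicity, read by MTT assay, with a stated time of 72 h; a higher number here means that more compound is tolerated, a lower number that less compound is tolerated. In this assay compound 2 gives > 3900 nM, a limit of the assay rather than a number. Compound 1 `O=[N+]([O-])c1c(CS(=O)(=O)c2ccccc2)nc2c(C#Cc3cccc(F)c3)cc(Cl)cn12` likewise gives > 3900 nM, also a limit. Compound 3 `CC(C)(O)C#Cc1cc(Cl)cn2c([N+](=O)[O-])c(CS(=O)(=O)c3ccccc3)nc12` gives > 62500 nM, again a limit. With only limits in hand, the steps a step that the two limits leave unreadable from compound 1 to compound 2, a step that the two limits leave unreadable from compound 1 to compound 3 and a step that the two limits leave unreadable from compound 2 to compound 3 have no readable size. Compound 4 `O=[N+]([O-])c1c(CS(=O)(=O)c2ccccc2)nc2c(C#CC3(O)CCCC3)cc(Cl)cn12` differs from compound 2 by 1-hydroxycyclopentyl in place of 2-fluorophenyl on a triple-bonded carbon. The change resembles that from compound 2 to compound 3, where the alcohol-bearing compound 3 reached the higher limit (the limit of > 62500 nM in this assay, at which 1 of the 3 values shown sits), while compound 2 sits at the limit of > 3900 nM in this assay, at which 2 of the 3 values shown sit. Compound 4 is therefore estimated at 40000 nM, with a range from 8000 nM to 100000 nM. That estimate means an expected step that the limit leaves unreadable from compound 2 to compound 4.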

Compound 4, half-maximal cytotoxic concentration: > 31300 nM
Compound 4: no number, only a limit (the forecaster's own chance of this, stated with the estimate: 70%); the middle value does not contradict the limit.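

In this assay compound 4 gives > 31300 nM, a limit and not a number. Its steps to compound 1, compound 2 and compound 3 cannot be read. The compounds shown leave open the actual half-maximal cytotoxic concentration of all four.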